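Swapping the fluorophenyl group on the acetamido compound

The source may report more compounds than this note shows. Statements on the series, on what has been measured and on what is new or still open speak of the compounds shown alone.

compound 1 `COc1cc(/C=C2\CN(S(=O)(=O)c3ccc(F)cc3)C/C(=C\c3ccccc3F)C2=O)cc(OC)c1OC`: 13300 nM
compound 2 `COc1cc(/C=C2\CN(S(=O)(=O)c3ccc(NC(C)=O)cc3)C/C(=C\c3ccccc3F)C2=O)cc(OC)c1OC`: 2680 nM

In a functional assay on QGY-7703 cells (Homo sapiens) for cytotoxicity, read by MTT assay, with a stated time of 24 h (on this read-out lower numbers stand for stronger inhibition and higher numbers for weaker inhibition), compound 2 holds the lower of the two numbers, at 2680 nM. The next compound, compound 3 `COc1cc(/C=C2\CN(S(=O)(=O)c3ccc(NC(C)=O)cc3)C/C(=C\c3cc(OC)c(OC)c(OC)c3)C2=O)cc(OC)c1`, keeps its acetamido group but differs as follows: 3,5-dimethoxyphenyl in place of 2-fluorophenyl on a double-bonded chain carbon bound to a double-bonded ring carbon. In words, 3,5-dimethoxyphenyl stands in place of 2-fluorophenyl on a double-bonded chain carbon bound to a double-bonded ring carbon. Going by the values given here, the one measured step, a 5.0-fold lower number from compound 1 to compound 2 (0.70 log units; beyond the scatter), is modest and concerns a different change, so no measured step bears directly on this swap. With no guide to direction, no shift beyond the scatter is expected, and the estimated step is a 1.1-fold higher number from compound 2 to compound 3 (0.05 log units; within the scatter). The expected value for compound 3 is 3000 nM, within an estimated range of 900 nM to 10000 nM.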

Compound 3, half-maximal inhibitory concentration: 2020 nM
Compound 3: the middle estimate sits 1.5-fold (0.17 log units) above what was measured; the measured number falls inside the stated range.
By their numbers in this assay, from the lowest: compounds 3 and 2 (each within the scatter of the next); then compound 1.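

Placing 3,5-dimethoxyphenyl in place of 2-fluorophenyl gives a 1.3-fold lower number from compound 2 to compound 3 (0.12 log units; within the scatter) in this assay on a double-bonded chain carbon bound to a double-bonded ring carbon. With the acetamido group present, this position therefore takes a group of 10 heavy atoms instead of 7, and 2 hydrogen-bond acceptors instead of 0, without a shift beyond the scatter. Nothing available explains this result. From the compounds shown here alone, whether a phenyl group carrying an amine or a carboxylic acid at this carbon would shift the number beyond the scatter remains open, as does whether the same swap would behave alike with fluoro in place of acetamido.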